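Cyclopropane diamide series: amide aryl variation in compound 4

The source may hold more compounds than are shown below. What is called first, only, known or untested is meant among the compounds shown, and "the series" means these compounds.

Measured compounds:
compound 1 `CN(C)C(=O)c1cc2cnc(Nc3ccc(NC(=O)C4(C(=O)Nc5cccc(O)c5)CC4)cc3)nc2n1C1CCCC1` 78.5%
compound 2 `CN(C)C(=O)c1cc2cnc(Nc3ccc(NC(=O)C4(C(=O)Nc5ccc(Br)cc5)CC4)cc3)nc2n1C1CCCC1` 76.9%
compound 3 `CN(C)C(=O)c1cc2cnc(Nc3ccc(NC(=O)C4(C(=O)Nc5ccc(O)cc5)CC4)cc3)nc2n1C1CCCC1` 89.7%

In a functional assay on NCI-H1299 cells (Homo sapiens) for inhibition, read by CCK-8 assay, with a stated time of 72 h, tested at 10 uM (a lower number here means less inhibition of growth, a higher number more inhibition of growth at the concentration tested), compound 3 stands highest of the three numbers. The two steps that lead up to it are a number 11.2 percentage points higher from compound 1 to compound 3 (beyond the scatter) and a number 12.8 percentage points higher from compound 2 to compound 3 (beyond the scatter), both beyond the scatter. Compound 1 and compound 2 lie within the scatter of each other: a number 1.6 percentage points lower from compound 1 to compound 2 (within the scatter).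

Compound 4 `CN(C)C(=O)c1cc2cnc(Nc3ccc(NC(=O)C4(C(=O)Nc5cccc(F)c5)CC4)cc3)nc2n1C1CCCC1` is not yet measured. Its change from compound 3 is 3-fluorophenyl in place of 4-hydroxyphenyl on an amide-type nitrogen.

Within the data shown here, two measured steps bear on this change. Moving the hydroxy from the 4-hydroxyphenyl to the 3-hydroxyphenyl arrangement cost a modest amount, and replacing hydroxy with bromo cost a similar amount. Compound 4 does both at once: the hydroxy is gone and a halogen sits on the 3-position of the phenyl. A modest drop in this assay is therefore expected, of about the size of either step rather than their sum, since compound 1 and compound 2 share roughly the same level.

The expected step from compound 3 is a number 13.7 percentage points lower from compound 3 to compound 4 (beyond the scatter). Compound 4 is estimated at 76%, with a range from 65% to 87%.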

Compound 4, percent growth inhibition at one concentration: 87%
Compound 4: middle estimate off by 11 percentage points, on the low side, within the range that was stated.
By their numbers in this assay, from the lowest: compounds 2, 1, 4 and 3 (each within the scatter of the next, the first and the last beyond it).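

In this assay, the hydroxy is not needed to hold the level at this amide-type nitrogen: 3-fluorophenyl, with 0 hydrogen-bond donors, replaces 4-hydroxyphenyl (a number 2.7 percentage points lower from compound 3 to compound 4 (within the scatter)). With the substituent at the same ring carbon, fluoro in place of hydroxy also stays within the scatter (a number 8.5 percentage points higher from compound 1 to compound 4 (within the scatter)), although compound 3 remains clear of compound 1. The step from 4-bromophenyl (a number 10.1 percentage points higher from compound 2 to compound 4 (beyond the scatter)) shows that the halogen-bearing aryl groups do not share one level, but it changes both the halogen and its place, so neither can be credited alone.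

As far as these compounds go, whether an amine or a carboxylic acid on this phenyl would hold the same level remains open. Nothing here gives a reason for any of these steps.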